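The source may hold more compounds than are shown below. What is called first, only, known or untested is meant among the compounds shown, and "the series" means these compounds.

Working notes on the series. In a functional assay on MDA-MB-231 cells (Homo sapiens) for cytotoxicity, read by MTT assay, with a stated time of 24 h (on this read-out lower numbers stand for stronger inhibition and higher numbers for weaker inhibition), compound 1 `Fc1ccc(-c2nc3cccnc3n2C2CCCC2)cc1` gives 500 nM, compound 2 `CCNC(=O)c1ccc(-c2nc3cccnc3n2C2CCCC2)cc1` gives 320 nM and compound 3 `Cc1nnc(-c2ccc(-c3nc4cccnc4n3C3CCCC3)cc2)o1` gives 21 nM. Compound 3 thus holds the lowest number of the three, and its steps to both others lie beyond the scatter.

Compound 4 `c1cncc(-c2ccc(-c3nc4cccnc4n3C3CCCC3)cc2)c1` is not yet measured. Its change from compound 3 is pyridin-3-yl in place of 5-methyl-1,3,4-oxadiazol-2-yl on an aromatic carbon, on an aromatic carbon of a six-membered aromatic ring of carbon only, para to a large group.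

All three measured steps concern this same place. Two of them are large: a 24-fold lower number from compound 1 to compound 3 (1.38 log units; beyond the scatter) and a 15-fold lower number from compound 2 to compound 3 (1.18 log units; beyond the scatter). The third, a 1.6-fold lower number from compound 1 to compound 2 (0.19 log units; within the scatter), stays within the scatter. Among these three compounds, then, the low number goes only with the 5-methyl-1,3,4-oxadiazol-2-yl group, and that group leaves in compound 4. Among the compounds with values here, no measured compound carries pyridin-3-yl, so the data do not show where it falls.

In this assay a move to a higher number is expected, probably smaller than the two large steps, and this expectation is uncertain. The estimated change is a 3.3-fold higher number from compound 3 to compound 4 (0.52 log units; beyond the scatter). The estimate for compound 4 is 70 nM, with an expected range of 18 nM to 320 nM.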

Compound 4, half-maximal inhibitory concentration: > 10000 nM
Compound 4: a limit, no number; the forecaster's own chance of this, stated with the estimate: 2%; middle value at least 140-fold (2.15 log units) from the limit.
By their numbers in this assay, from the lowest: compound 3; then compounds 2 and 1 (each within the scatter of the next). At a limit, above all of these: compound 4.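

Compound 4 gives no number in this assay, only a limit: the limit of > 10000 nM in this assay, at which 1 of the 4 values shown sits. Within the data shown here, the exchange of one aromatic ring for another of the same heavy-atom count, on an aromatic carbon of a six-membered aromatic ring of carbon only, para to a large group, gives an at least 470-fold higher number from compound 3 to compound 4 (2.67 log units; beyond the scatter), so this place separates two ring groups far more sharply than the earlier compounds showed. Pyridin-3-yl also falls behind both groups without a ring of their own, with an at least 31-fold higher number from compound 2 to compound 4 (1.49 log units; beyond the scatter) and an at least 20-fold higher number from compound 1 to compound 4 (1.30 log units; beyond the scatter), so an aromatic ring here does not by itself go with a low number: among the four compounds, ring groups stand at both ends of the series.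

The compounds shown do not separate what in the 5-methyl-1,3,4-oxadiazol-2-yl group goes with the low number, whether its methyl, its oxygen or its ring size, and a phenyl ring, an oxadiazole ring without the methyl or a carboxylic acid at this place would bear on that. As far as these compounds go, how far compound 4 lies beyond its limit also stays open.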